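Methyl in Place of Trifluoromethyl: What the Data Suggest

The compounds below may be only part of what the source reports. "The series", "measured", "known", "first", "only" and "open" are said of these compounds alone.

Of the compounds shown here, three built on one shared core have been tested in a functional assay on Jurkat cells (Homo sapiens) for antiproliferative activity, read by MTT assay, with a stated time of 48 h; on this read-out lower numbers stand for stronger inhibition and higher numbers for weaker inhibition. Compound 1 `COC(=O)/C=C/c1ccc2c(c1)C(=O)C(=O)N2Cc1ccccc1` gives 70 nM. Compound 2 `COC(=O)/C=C/c1ccc2c(c1)C(=O)C(=O)N2Cc1ccc(C#N)cc1` gives 80 nM, and a 1.1-fold higher number from compound 1 to compound 2 (0.06 log units; within the scatter). Compound 3 `COC(=O)/C=C/c1ccc2c(c1)C(=O)C(=O)N2Cc1ccc(C(F)(F)F)cc1` gives 360 nM, the highest of the three numbers: a 5.1-fold higher number from compound 1 to compound 3 (0.71 log units; beyond the scatter), and a 4.5-fold higher number from compound 2 to compound 3 (0.65 log units; beyond the scatter).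

Compound 4 `COC(=O)/C=C/c1ccc2c(c1)C(=O)C(=O)N2Cc1ccc(C)cc1` differs from compound 3 by methyl in place of trifluoromethyl on an aromatic carbon. Going by the values given here, no measured pair shows methyl at this place, so the expectation rests on the two steps that put trifluoromethyl there, namely a 5.1-fold higher number from compound 1 to compound 3 (0.71 log units; beyond the scatter) and a 4.5-fold higher number from compound 2 to compound 3 (0.65 log units; beyond the scatter), both modest and beyond the scatter. Taking trifluoromethyl away is therefore expected to lower the number again, most likely toward the range where compound 1 and compound 2 sit, although the lack of a direct precedent leaves room for a smaller move. The step expected here is a 3.0-fold lower number from compound 3 to compound 4 (0.48 log units; beyond the scatter). Compound 4 is accordingly estimated at 120 nM, with a range from 50 nM to 350 nM.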

Compound 4, half-maximal inhibitory concentration: 50 nM
For compound 4 the middle estimate is 2.4-fold (0.38 log units) above the measured one; measured number inside the range.
By their numbers in this assay, from the lowest: compounds 4, 1 and 2 (each within the scatter of the next); then compound 3.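

In this assay, going by these compounds alone, methyl gives the first comparison of trifluoromethyl with another carbon-bearing group at this place, and a 7.2-fold lower number from compound 3 to compound 4 (0.86 log units; beyond the scatter) shows that the weaker result of compound 3 does not extend to this small carbon group. Methyl is also not separated from hydrogen or cyano: a 1.4-fold lower number from compound 1 to compound 4 (0.15 log units; within the scatter) and a 1.6-fold lower number from compound 2 to compound 4 (0.20 log units; within the scatter) both stay within the scatter, so among these four compounds only compound 3 goes against an otherwise flat picture. Nothing available explains why trifluoromethyl alone stands apart.

The compounds shown leave open whether an amine, a carboxylic acid or a longer chain at this place would stay with compound 1, compound 2 and compound 4 or move toward compound 3. They also leave open whether the step from trifluoromethyl to methyl would keep its size on another core.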